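The source may hold more compounds than are shown below. What is called first, only, known or untested is meant among the compounds shown, and "the series" means these compounds.

Three compounds have been measured in a functional assay with Alpha-1B adrenergic receptor (Homo sapiens) as the target, read by calcium flux; on this read-out lower numbers stand for smaller maximal responses and higher numbers for larger maximal responses:

compound 1 `Cc1n[nH]c(-c2ccccc2NCC2=NCCN2)n1` gives 0%
compound 2 `c1ccc(-c2cn[nH]c2)c(NCC2=NCCN2)c1` gives 72%
compound 3 `CCn1cc(-c2ccccc2NCC2=NCCN2)cn1` gives 0%

Compound 2 stands highest of the three numbers in this assay, and both other compounds lie far from it: a number 72 percentage points higher from compound 1 to compound 2 (beyond the scatter), and a number 72 percentage points lower from compound 2 to compound 3 (beyond the scatter). In this small set, only compound 2 reaches a sizeable maximal response at all.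

Compound 4 `Cn1ccnc1-c1ccccc1NCC1=NCCN1` has not yet been measured. It differs from compound 2 in one place: 1-methyl-1H-imidazol-2-yl in place of 1H-pyrazol-4-yl on an aromatic carbon. For the measured compounds named here, two measured steps bear on this change. The step from compound 2 to compound 3, ethyl in place of hydrogen on an aromatic nitrogen, also removes the hydrogen-bond donor of the five-membered ring and was large, a number 72 percentage points lower from compound 2 to compound 3 (beyond the scatter). The step from compound 1 to compound 2, which exchanged one five-membered aromatic ring with two hetero atoms for another, was equally large, a number 72 percentage points higher from compound 1 to compound 2 (beyond the scatter), showing that the identity of this ring alone moves the number across its whole span. Compound 4 changes both the ring and the donor count at once, so a large fall in this assay is expected, a number 62 percentage points lower from compound 2 to compound 4 (beyond the scatter). Compound 4 is therefore estimated at 10%, within a range from 0% to 45%.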

Compound 4, largest response reached (reported as maximal response), in percent of the reference or control that the assay uses: 104%
The estimate for compound 4 lay 94 percentage points below the measured number; the measured number lies above the stated range.
By their numbers in this assay, from the lowest: compounds 1 and 3 (each within the scatter of the next); then compound 2; then compound 4.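

In this assay, the change to 1-methyl-1H-imidazol-2-yl gives a number 32 percentage points higher from compound 2 to compound 4 (beyond the scatter), so on this aromatic carbon a five-membered aromatic ring with 0 hydrogen-bond donors can carry a larger maximal response than 1H-pyrazol-4-yl, while compound 3, which also has no donor on its ring, gives 0%. The loss of the donor therefore does not by itself set the number at this position, and the exchange of 3-methyl-1H-1,2,4-triazol-5-yl for the same imidazole, a number 104 percentage points higher from compound 1 to compound 4 (beyond the scatter), shows that the choice of ring here spans the whole range of the set. Nothing available accounts for why this ring gives the larger response.

The compounds shown leave open whether the methyl group matters, since 1H-imidazol-2-yl without it does not appear among them, and whether a longer chain such as propyl on the same ring nitrogen would keep the response. They also leave open whether a six-membered ring such as pyridin-2-yl on this carbon would give a response of similar size.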